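Cytotoxicity in HEL cells across a small sulfonate series

The compounds below may be only part of what the source reports. "The series", "measured", "known", "first", "only" and "open" are said of these compounds alone.

Measured compounds:
compound 1, `CCC1(Cc2ccccc2)OS(=O)(=O)C=C1OCc1ccccc1Cl`, 38000 nM
compound 2, `CCCC1(Cc2ccccc2)OS(=O)(=O)C=C1OCc1ccccc1`, 200000 nM
compound 3, `CC1(Cc2ccccc2)OS(=O)(=O)C=C1OCc1ccccc1`, 68000 nM

In an ADME assay on HEL cells (Homo sapiens) for cytotoxicity, with a stated time of 3 days (on this read-out lower numbers stand for higher toxicity in this test and higher numbers for lower toxicity in this test), compound 1 gives the lowest of the three numbers. Its nearest neighbour is compound 3, whose 68000 nM lies within the scatter of it, while the gap to compound 2 at 200000 nM is beyond the scatter. Within the data shown here, the only step between neighbours that differ in one place, a 2.9-fold lower number from compound 2 to compound 3 (0.47 log units; beyond the scatter), concerns the chain on the saturated ring carbon and does not touch the part of the molecule that changes here.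

Compound 4, `CCC1(Cc2ccccc2)OS(=O)(=O)C=C1OCCc1ccccc1`, differs from compound 1 as follows: benzyl in place of 2-chlorophenyl on a saturated chain carbon bound to an oxygen on an unsaturated carbon. Among the measured compounds shown here, no measured pair shows the effect of this change, so there is no basis for expecting a step beyond the scatter in either direction. Compound 4 is therefore expected to give 50000 nM in this assay, with a range from 15000 nM to 160000 nM. The step this estimate implies, a 1.3-fold higher number from compound 1 to compound 4 (0.12 log units; within the scatter), is expected to stay within the scatter.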

Compound 4, half-maximal cytotoxic concentration: 48000 nM
The estimate for compound 4 lay 1.0-fold (0.02 log units) above the measured number, and the stated range covers the measured number.
By their numbers in this assay, from the lowest: compounds 1, 4 and 3 (each within the scatter of the next); then compound 2.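

In this assay, among these compounds, the exchange on the saturated chain carbon bound to an oxygen on an unsaturated carbon gives the first reading at this place, a 1.3-fold higher number from compound 1 to compound 4 (0.10 log units; within the scatter). The group can therefore pass from 2-chlorobenzyl to phenethyl, with the same count of heavy atoms but without the chlorine, and the two compounds cannot be told apart here. The only earlier step, a 2.9-fold lower number from compound 2 to compound 3 (0.47 log units; beyond the scatter), lay beyond the scatter but concerned the chain on the saturated ring carbon, and nothing shown here gives a reason for the present result.

Among the compounds shown here, the single step leaves open whether losing the chlorine and lengthening the link each matter on their own, since both happen together. It also leaves open how an amine or a carboxylic acid on the phenethyl ring would read at this place.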